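This account rests on a few compounds, and the source may have more. Where it says the series, first, only, none or still open, it means among the compounds named here.

Working notes on the series: the three measured compounds share one core and differ only in the aryl group on an aromatic nitrogen. In a functional assay on Jurkat cells (Homo sapiens) for antiproliferative activity, read by MTT assay, with a stated time of 72 h (on this read-out lower numbers stand for stronger inhibition of growth and higher numbers for weaker inhibition of growth), compound 1 `Cc1c(C(=O)Nc2ccc(SC#N)cc2)nnn1-c1ccc(C(C)C)cc1` gives 690 nM, compound 2 `Cc1ccc(-n2nnc(C(=O)Nc3ccc(SC#N)cc3)c2C)cc1C` gives 680 nM and compound 3 `Cc1ccc(Cl)cc1-n1nnc(C(=O)Nc2ccc(SC#N)cc2)c1C` gives 680 nM. Compound 2 stands level with compound 3 at the digits given, and compound 1 lies within the scatter of both.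

The change leading to compound 4 `Cc1ccc(Cl)c(-n2nnc(C(=O)Nc3ccc(SC#N)cc3)c2C)c1` is 2-chloro-5-methylphenyl in place of 3,4-dimethylphenyl on an aromatic nitrogen, at the place next to the ring atom that bears a methyl group. Three measured swaps at this place bear on it. The closest is no change at the digits printed from compound 2 to compound 3 (within the scatter), which also replaces 3,4-dimethylphenyl with a group holding one chlorine and one methyl. The other two, a 1.0-fold lower number from compound 1 to compound 2 (0.01 log units; within the scatter) and a 1.0-fold lower number from compound 1 to compound 3 (0.01 log units; within the scatter), are equally small. Going by the values given here, all three stay within the scatter, although no measured compound carries 2-chloro-5-methylphenyl itself, so this remains an extrapolation from a flat set of three.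

In this assay the expected change is a 1.0-fold higher number from compound 2 to compound 4 (0.01 log units; within the scatter), so no step beyond the scatter is expected in either direction. Compound 4 is estimated at 700 nM, with an expected range from 350 nM to 1400 nM in this measurement.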

Compound 4, concentration for 50% growth inhibition: 66300 nM
Compound 4: middle estimate off by 95-fold (1.98 log units), on the low side; the whole stated range lies below it.
By their numbers in this assay, from the lowest: compounds 2, 3 and 1 (each within the scatter of the next); then compound 4.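

In this assay the aryl group on the aromatic nitrogen turns out not to be a tolerant place: there is a 98-fold higher number from compound 2 to compound 4 (1.99 log units; beyond the scatter), a 96-fold higher number from compound 1 to compound 4 (1.98 log units; beyond the scatter) and a 98-fold higher number from compound 3 to compound 4 (1.99 log units; beyond the scatter), whereas the three earlier compounds stayed within the scatter of one another and gave no hint of such a step. The comparison with compound 3 is the most telling, since 5-chloro-2-methylphenyl and 2-chloro-5-methylphenyl each hold one chlorine and one methyl, so exchanging the places of these two groups on the aryl ring is enough to weaken growth inhibition this much, and similarity in group size or atom count does not predict the outcome here. Nothing available gives a reason for this large step.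

As far as these compounds go, it remains open whether the step belongs to the chlorine of 2-chloro-5-methylphenyl itself or to the whole arrangement, which a fluorine, a methoxy group or a further methyl in place of that chlorine would help to separate. Also open, from the compounds shown here alone, is whether the step persists when the methyl on the five-membered ring gives way to hydrogen or an ethyl chain.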